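The source may hold more compounds than are shown below. What is called first, only, known or untested is meant among the compounds shown, and "the series" means these compounds.

- Compound 1 `C=CC(C)(C)OC[n+]1ccn(C)c1/C=N/O`: 7.94
- Compound 2 `C=C(C)CC(OC[n+]1ccn(C)c1/C=N/O)C(=C)C`: 7.91

For the measured compounds named here, in a physicochemical assay for acid dissociation, only two compounds have been measured so far. Compound 1 gives 7.94 and compound 2 gives 7.91. These two values lie within the usual scatter of each other, so they cannot be ranked.

The next compound to be measured is compound 3 `C#CC(C)OC[n+]1ccn(C)c1/C=N/O`. Its structure differs from that of compound 1 by 1-methylprop-2-yn-1-yl in place of 1,1-dimethylprop-2-en-1-yl on an oxygen on a saturated carbon.

Going by the values given here, no measured step shows what this change does, so any forecast is tentative. Among the compounds with values here, the closeness of compound 1 and compound 2, at 7.91, gives the only guide and suggests a modest shift. A small downward move is expected, estimated as a number 0.14 log units lower from compound 1 to compound 3 (within the scatter), and it may not clear the scatter. For compound 3, the estimated value is 7.8, with an expected range from 7.5 to 8.05.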

Compound 3, acid dissociation constant: 7.96
The estimate for compound 3 lay 0.16 log units below the measured number; the measured number falls inside the stated range.
By their numbers in this assay, from the lowest: compounds 2, 1 and 3 (each within the scatter of the next).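

For the compounds shown here, the first one-place step at this position comes from placing 1-methylprop-2-yn-1-yl in place of 1,1-dimethylprop-2-en-1-yl on an oxygen on a saturated carbon, and in this assay it reads a number 0.02 log units higher from compound 1 to compound 3 (within the scatter) and so cannot be told apart from no change. The two groups differ in their heavy-atom count and in carrying a triple bond rather than a double bond, yet this swap leaves no readable mark on the number. Nothing measured here explains this result.

Going by these compounds alone, this is a single step, and all the groups seen at this position so far are hydrocarbon chains with a double or triple bond. From the compounds shown here alone, whether an amine, a carboxylic acid or a plain saturated chain such as ethyl on the same oxygen would shift the number beyond the scatter remains open.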